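The source may hold more compounds than are shown below. What is called first, only, known or untested is meant among the compounds shown, and "the series" means these compounds.

Measured so far:
- compound 1, `CS(=O)(=O)Nc1ccc(C(C(=O)NCc2ccc(C(F)(F)F)nc2SC2CCCCC2)c2ccc(F)cc2)cc1F`: 37.6 nM
- compound 2, `CS(=O)(=O)Nc1ccc(C(Cc2ccccc2)C(=O)NCc2ccc(C(F)(F)F)nc2SC2CCCCC2)cc1F`: "active" (no number reported)

Among the compounds with values here, compound 1 carries a fluorophenyl group directly on the acetamide carbon and is the one member of the series with a number: in an assay on CHO cells for antagonist activity at transient receptor potential cation channel subfamily V member 1 (Homo sapiens), read by FLIPR (a higher number here means a weaker inhibitor, a lower number a stronger inhibitor), compound 1 gives 37.6 nM. Compound 2 instead carries a benzyl group at that position; in this assay compound 2 is reported as "active" (no number reported), without a number, so its standing relative to compound 1 cannot be put into numbers. Nothing else in the two structures differs; the sulfonamide-bearing ring, the amide and the cyclohexylthio-substituted pyridine core are shared.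

Compound 3, `CS(=O)(=O)Nc1ccc(C(Cc2ccc(F)cc2)C(=O)NCc2ccc(C(F)(F)F)nc2SC2CCCCC2)cc1F`, keeps the whole of compound 2 apart from one change, (fluoro in place of hydrogen on an aromatic carbon). Within the data shown here, no step between measured compounds is available to calibrate this. For a single fluoro in place of hydrogen on the outer ring, no shift in this assay beyond the usual scatter is expected in either direction.

Compound 3 is expected to give about 50 nM in this assay, with a plausible range from 10 nM to 250 nM, the spread reflecting that compound 2 itself has no number.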

Compound 3, inhibition constant: "active" (no number reported)
Compound 3 has no reported number here; there is nothing to compare the estimate with.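

In this assay compound 2 and compound 3 are both reported only as active, so no step can be read from compound 2 to compound 3. Nothing available bears on this result. The compounds shown leave open whether phenyl to 4-fluorophenyl shifts inhibition at all, and how compound 2 and compound 3 stand numerically against compound 1.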